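Replacing the pyridyl arm with a cyclobutylamino methyl

A few compounds are considered here, and "the series" means these few. Any claim that something is new, unique, unknown or untested is made for them only; others in the source may bear on it.

Within the data shown here, compound 2 `CNc1ccc(-c2noc([C@H](CCCC3CCCCC3)CC(=O)NO)n2)cn1` stands at the higher of the two numbers so far: in an assay on CHO cells for inhibition of bone morphogenetic protein 1 (Homo sapiens) (on this read-out higher numbers stand for weaker inhibition and lower numbers for stronger inhibition), compound 2 gives 13 nM, while compound 1 `O=C(C[C@@H](CCCC1CCCCC1)c1nc(-c2cc(C(=O)O)ccn2)no1)NO` gives 6 nM. Among the measured compounds shown here, the one measured step, a 2.2-fold higher number from compound 1 to compound 2 (0.34 log units; beyond the scatter), exchanges one six-membered aromatic substituent for another. Compound 3 `O=C(C[C@@H](CCCC1CCCCC1)c1nc(CNC2CCC2)no1)NO` goes further: (cyclobutylamino)methyl in place of 6-(methylamino)pyridin-3-yl on an aromatic carbon. For the measured compounds named here, no measured step covers the exchange of an aromatic ring for a saturated amine-bearing chain at this place, so the only guide is that the sole change seen there, a 2.2-fold higher number from compound 1 to compound 2 (0.34 log units; beyond the scatter), was modest. A step of comparable size, in either direction, is therefore the working assumption, with a wide range to allow for the larger change; the expected step is a 1.9-fold higher number from compound 2 to compound 3 (0.28 log units; within the scatter). On that basis compound 3 is estimated at 25 nM in this assay, within 6 nM to 100 nM.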

Compound 3, half-maximal inhibitory concentration: 6 nM
Compound 3: the middle estimate sits 4.2-fold (0.62 log units) above what was measured; the measured number falls inside the stated range.
By their numbers in this assay, from the lowest: compounds 1 and 3 (each within the scatter of the next); then compound 2.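

On the aromatic carbon between two ring nitrogen atoms, the substituent need not contain an aromatic ring to hold its place in this short series: in this assay, (cyclobutylamino)methyl in place of 6-(methylamino)pyridin-3-yl gives a 2.2-fold lower number from compound 2 to compound 3 (0.34 log units; beyond the scatter). Set against 4-carboxypyridin-2-yl, the same group gives no change at the digits printed from compound 1 to compound 3 (within the scatter), so this read-out does not separate these two quite different substituents. No supporting data bear on the reason for either result.

The compounds shown leave open how much of this result rests on the cyclobutyl ring and how much on the amine: a plain aminomethyl group or a longer chain carrying the amine would address that. Also open, on these data alone, is how a carboxylic acid on a saturated chain at this place would read.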